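Cytotoxicity on HEL cells across a uracil pentyl ether series

The compounds below may be only part of what the source reports. "The series", "measured", "known", "first", "only" and "open" are said of these compounds alone.

Compound 1 `Cc1cccc(OCCCCCn2ccc(=O)[nH]c2=O)c1` is assessed in an ADME assay on HEL cells (Homo sapiens) for cytotoxicity; a higher number here means that more compound is tolerated, a lower number that less compound is tolerated. Compound 1 gives > 100000 nM, which is a limit of the assay and not a number. Compound 2 `Cc1cc(C)cc(OCCCCCn2ccc(=O)[nH]c2=O)c1` differs by methyl in place of hydrogen on an aromatic carbon and gives > 100000 nM, again a limit. Compound 3 `O=c1ccn(CCCCCOc2ccc(Br)cc2)c(=O)[nH]1` carries a different core, the difference being (4-bromophenyl in place of 3-methylphenyl on an oxygen on a saturated carbon); compound 3 gives > 100000 nM, also a limit. Accordingly the steps a step that the two limits leave unreadable from compound 1 to compound 2 and a step that the two limits leave unreadable from compound 1 to compound 3 cannot be sized, since the limit of > 100000 nM in this assay, at which 3 of the 3 values shown sit, holds for every value so far.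

Compound 4 `Cc1cn(CCCCCOc2ccc(Br)cc2)c(=O)[nH]c1=O` is not yet measured. It differs from compound 3 by methyl in place of hydrogen on an aromatic carbon, the same kind of change as from compound 1 to compound 2, though here the place is on a six-membered aromatic ring with 2 nitrogen rather than a ring of carbon only. Given (the limit of > 100000 nM in this assay, at which 3 of the 3 values shown sit), the step from compound 3 to compound 4 is expected to be a step that the limit leaves unreadable from compound 3 to compound 4. Compound 4 is therefore estimated at 150000 nM in this assay.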

Compound 4, half-maximal cytotoxic concentration: > 100000 nM
Compound 4 gave a limit, no number; the forecaster's own chance of this, stated with the estimate: 85%; the middle value lies beyond the limit too.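

Compound 3 and compound 4 both sit at a limit and not at a number, so no step between them can be read: the limit of > 100000 nM in this assay, at which 4 of the 4 values shown sit.

The compounds shown leave open at what concentration any of the four would become cytotoxic in this assay.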